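Swapping an Ester for a Diethylamide

The compounds below may be only part of what the source reports. "The series", "measured", "known", "first", "only" and "open" are said of these compounds alone.

Compound 1 `OC(c1ccccc1)(c1ccccc1)C1CCN(C(=S)Nc2ccc(OC(F)(F)F)cc2)CC1` gives 1050 nM in a functional assay for antagonist activity at Neuropeptide Y receptor type 2 (Homo sapiens); a lower number here means a stronger inhibitor, a higher number a weaker inhibitor.
Compound 2 `CCCc1ccc(NC(=S)N2CCC(C(O)(c3ccccc3)c3ccccc3)CC2)cc1` gives 777 nM in this assay.
Compound 3 `CCOC(=O)c1ccc(NC(=S)N2CCC(C(O)(c3ccccc3)c3ccccc3)CC2)cc1` gives 207 nM in this assay.

Of these three, compound 3 has the lowest number. The step of a 5.1-fold lower number from compound 1 to compound 3 (0.71 log units; beyond the scatter) and the step of a 3.8-fold lower number from compound 2 to compound 3 (0.57 log units; beyond the scatter) both lie beyond the scatter, whereas a 1.4-fold lower number from compound 1 to compound 2 (0.13 log units; within the scatter) does not. So the ethoxycarbonyl group on the aromatic carbon is what sets compound 3 apart from the other two; trifluoromethoxy and propyl behave alike.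

Compound 4 `CCN(CC)C(=O)c1ccc(NC(=S)N2CCC(C(O)(c3ccccc3)c3ccccc3)CC2)cc1` keeps everything of compound 3 except one change: diethylamino in place of ethoxy on a carbonyl carbon. Among the measured compounds shown here, no measured step touches this part of the molecule. The two steps that lead to compound 3 only show that an ethoxycarbonyl group lowers the number compared with trifluoromethoxy or propyl; they say nothing about whether a diethylcarbamoyl group holds that gain, loses it, or improves on it. The swap removes the only hydrogen-bond acceptor of the leaving group and adds two heavy atoms, and that is all that can be said from the structures.

The expectation is therefore a modest step upward with wide uncertainty: the step of a 1.7-fold higher number from compound 3 to compound 4 (0.23 log units; within the scatter) is expected in this assay. Compound 4 is estimated to give 350 nM, with a likely range from 100 nM to 1200 nM.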

Compound 4, half-maximal inhibitory concentration: 78 nM
Beside the measured number, compound 4's estimate is 4.5-fold (0.65 log units) above it, outside the stated range (below it).
By their numbers in this assay, from the lowest: compound 4; then compound 3; then compounds 2 and 1 (each within the scatter of the next).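

The earlier compounds shown here compared only whole groups on the aromatic carbon, whereas in this assay this change shows that the part on the carbonyl carbon also moves the number, with diethylamino in place of ethoxy giving a 2.7-fold lower number from compound 3 to compound 4 (0.42 log units; beyond the scatter) as the step at this position. A low number therefore does not depend on the ethoxy group or on the hydrogen-bond acceptor counted for it, and the carbonyl carbon can carry the larger diethylamino group of 5 heavy atoms. Measured against the two groups that showed no clear difference from each other, diethylcarbamoyl stands well apart, with a 10-fold lower number from compound 2 to compound 4 (1.00 log units; beyond the scatter) for the change from propyl and a 13-fold lower number from compound 1 to compound 4 (1.13 log units; beyond the scatter) for the change from trifluoromethoxy.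

The compounds shown leave open whether a shorter dimethylamino group, a longer dipropylamino group, a ring amine such as pyrrolidine or a free carboxylic acid at this carbonyl carbon would lower the number further or lose the gain. Nothing at hand accounts for the step, so the reason for it remains unknown.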